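The compounds below may be only part of what the source reports. "The series", "measured", "known", "first", "only" and "open" are said of these compounds alone.

Notes on a three-membered set and one untested analogue.

Compound 1 `CC(c1ccc(-c2ccccc2)c(F)c1)c1nnc2n1N=C(c1ccc(OC(F)(F)F)cc1)CS2` carries a 4-(trifluoromethoxy)phenyl arm on a shared core; in a functional assay on MCF7 cells (Homo sapiens) for inhibition, read by sulforhodamine B assay, with a stated time of 72 h (on this read-out higher numbers stand for weaker inhibition and lower numbers for stronger inhibition), compound 1 gives 4800 nM. Compound 2 `CC(c1ccc(-c2ccccc2)c(F)c1)c1nnc2n1N=C(c1ccccc1)CS2` is the plain phenyl counterpart, and in this assay compound 2 gives 7400 nM. The difference between them is trifluoromethoxy in place of hydrogen on an aromatic carbon, and the size of that step is a 1.5-fold lower number from compound 2 to compound 1 (0.19 log units; within the scatter).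

Compound 3 `CC(C)Cc1ccc(C(C)c2nnc3n2N=C(c2ccccc2)CS3)cc1` shares the phenyl arm of compound 2 but rests on a different core; the difference between the two cores is not broken down here. In this assay compound 3 gives 9700 nM, which stands within the scatter of compound 2 and beyond the scatter of compound 1 only.

Compound 4 `CC(C)Cc1ccc(C(C)c2nnc3n2N=C(c2ccc(OC(F)(F)F)cc2)CS3)cc1` has not been tested. It differs from compound 3 by trifluoromethoxy in place of hydrogen on an aromatic carbon, the same change that separates compound 2 from compound 1, and at the same place. Since the one worked example of this change, the step of a 1.5-fold lower number from compound 2 to compound 1 (0.19 log units; within the scatter), stays inside the scatter, the expectation for compound 4 is a step of similar size: an estimated 1.5-fold lower number from compound 3 to compound 4 (0.17 log units; within the scatter) in this assay, resting on a single precedent and on the value of compound 3 as the starting point. On that basis compound 4 is expected to give about 6500 nM in this assay, with a plausible range from 3000 nM to 14000 nM.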

Compound 4, half-maximal inhibitory concentration: 1100 nM
Compound 4: middle estimate off by 5.9-fold (0.77 log units), on the high side; measured number below the stated range.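

In this assay, trifluoromethoxy in place of hydrogen on an aromatic carbon gives an 8.8-fold lower number from compound 3 to compound 4 (0.95 log units; beyond the scatter), so the size of this step does not carry over from the core of compound 2 to the core of compound 3: the same change on two cores in this assay, a 1.5-fold lower number (0.19 log units; within the scatter) from compound 2 to compound 1 and an 8.8-fold lower number (0.95 log units; beyond the scatter) from compound 3 to compound 4, 5.7-fold (0.76 log units) apart, beyond the scatter of two such steps

Going by these compounds alone, only the step on the core of compound 3 lies beyond the scatter, while the earlier step lies within it, so a step measured on one core is a poor guide to its size on the other. With a single pair on each core, the data do not show which of the two steps is more typical of the series, nor which part of the difference between the cores goes with the gap, and they give no cause for it.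

From the compounds shown here alone, whether other groups at the same place, such as methoxy, trifluoromethyl or a carboxylic acid, also give steps that differ between these two cores stays open. Also open, going by these compounds, are how trifluoromethoxy behaves on a third core, for instance one carrying an amine, and whether the large step on the core of compound 3 holds up in repeated measurements.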